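Methoxy for Methyl Across Two Cores

The source may hold more compounds than are shown below. What is called first, only, known or untested is meant among the compounds shown, and "the series" means these compounds.

Compound 1 `Cc1ccc(N2CCN/C2=N\N)cc1` and compound 2 `COc1ccc(N2CCN/C2=N\N)cc1` share one core. In a functional assay on T47D cells (Homo sapiens) for cytotoxicity, with a stated time of 72 h, tested at 50 ug/mL (a higher number here means a stronger effect of the compound at the concentration tested, a lower number a weaker effect), compound 1 gives 17% and compound 2 gives 23%; the change methoxy in place of methyl on an aromatic carbon made a number 6 percentage points higher from compound 1 to compound 2 (within the scatter).

Compound 3 `Cc1ccccc1N1CCn2c1n[nH]c(=O)c2=O` is built on another core; the difference between the two cores is not broken down here. In this assay compound 3 gives 0%, the lowest of the three numbers. Compound 4 `COc1ccccc1N1CCn2c1n[nH]c(=O)c2=O` is not yet measured and differs from compound 3 by methoxy in place of methyl on an aromatic carbon. This is the same kind of change as that from compound 1 to compound 2, but not the same: there the group entered para to a group of 7 heavy atoms, here it enters ortho to a large group.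

The step from compound 3 to compound 4 is expected to be small, a number 5 percentage points higher from compound 3 to compound 4 (within the scatter), because the earlier exchange gave a number 6 percentage points higher from compound 1 to compound 2 (within the scatter). For compound 4 in this assay the expected value is 5%, between 0% and 15%.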

Compound 4, a percentage reported as inhibition, at one concentration (the size of the read-out at that concentration, not a potency): 9%
For compound 4 the middle estimate is 4 percentage points below the measured one; measured number inside the range.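

In this assay, methoxy in place of methyl on an aromatic carbon gave a number 9 percentage points higher from compound 3 to compound 4 (within the scatter). Set beside the earlier exchange, the two steps agree: the same change on two cores in this assay, a number 6 percentage points higher (within the scatter) from compound 1 to compound 2 and a number 9 percentage points higher (within the scatter) from compound 3 to compound 4, 3 percentage points apart, within the scatter of two such steps. This shows that the exchange stayed within the scatter on both cores, but it does not show a real effect of the change on either core, and two pairs give no rule for other cores or other places on the aromatic ring.

The compounds shown leave open how an amine, a carboxylic acid or a longer chain on the same aromatic carbon would read in this assay. They also leave open whether any replacement for methyl on either core moves the read-out beyond the scatter.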